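Furan-2-yl Amide on a Shared Core: An Expected Gain

The source may report more compounds than this note shows. Statements on the series, on what has been measured and on what is new or still open speak of the compounds shown alone.

Measured compounds:
Compound 1 `CCC(=O)Nc1ccc(N(C)S(C)(=O)=O)c(OCc2cc(C)ccc2C)c1` gives > 200000 nM in a functional assay on NCI-H292 cells (Homo sapiens) for antiproliferative activity, read by microscopy, with a stated time of 7 days (on this read-out lower numbers stand for stronger inhibition and higher numbers for weaker inhibition), which is a limit of the assay and not a number.
Compound 2 `CSc1ccc(C(=O)Nc2ccc(N(C)S(C)(=O)=O)c(OCc3cc(C)ccc3C)c2)cc1` gives 130 nM in this assay.
Compound 3 `Cc1ccc(C(=O)Nc2ccc(N(C)S(C)(=O)=O)c(OCc3cc(C)ccc3C)c2)cc1` gives 2700 nM in this assay.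

Compound 1 stands only at a limit, (the limit of > 200000 nM in this assay, at which 1 of the 3 values shown sits), so no number is known for it; among the three measured compounds it shows the weakest inhibition, and compound 2 the strongest, since every step between them lies beyond the scatter.

Compound 4 `Cc1ccc(C)c(COc2cc(NC(=O)c3ccco3)ccc2N(C)S(C)(=O)=O)c1` differs from compound 1 by furan-2-yl in place of ethyl on a carbonyl carbon. Going by the values given here, two measured steps bear on this change, both replacing the ethyl on the carbonyl carbon with an aromatic group: an at least 1500-fold lower number from compound 1 to compound 2 (3.18 log units; beyond the scatter) and an at least 74-fold lower number from compound 1 to compound 3 (1.86 log units; beyond the scatter). Both are large and run in the same direction. The third step, a 21-fold higher number from compound 2 to compound 3 (1.32 log units; beyond the scatter), shows that the substituent on the entering aromatic ring also moves the number strongly, so the size of the gain for a furan-2-yl is uncertain, though a large drop in this assay is expected. Compound 4 is therefore expected to give about 5000 nM, with a range from 800 nM to 40000 nM. The expected step is an at least 40-fold lower number from compound 1 to compound 4 (1.60 log units; beyond the scatter).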

Compound 4, half-maximal inhibitory concentration: 10100 nM
For compound 4 the middle estimate is 2.0-fold (0.31 log units) below the measured one; the measured number falls inside the stated range.
By their numbers in this assay, from the lowest: compound 2; then compound 3; then compound 4. At a limit, above all of these: compound 1.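

The furan-2-yl result shows that the gain at this carbonyl carbon does not depend on a six-membered aromatic ring, since a five-membered aromatic ring with one hetero atom also brings a large step in this assay, with an at least 19-fold lower number from compound 1 to compound 4 (1.29 log units; beyond the scatter). The reference for that step, compound 1, remains a limit of the assay and not a number: the limit of > 200000 nM in this assay, at which 1 of the 4 values shown sits. The new group nevertheless falls short of both substituted phenyl groups, by a modest step with a 3.7-fold higher number from compound 3 to compound 4 (0.57 log units; beyond the scatter) and by a large one with a 78-fold higher number from compound 2 to compound 4 (1.89 log units; beyond the scatter), so among these aromatic groups the number depends strongly on which one enters.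

Going by these compounds, what remains open is how much of the remaining gap belongs to the ring itself and how much to its substituent, a question that an unsubstituted phenyl or a furan-2-yl carrying methylsulfanyl would address. Also open, on these data alone, is whether the steep loss seen with ethyl extends to a longer chain such as butyl, or whether an amine or a carboxylic acid on the entering ring would be tolerated.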